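The compounds below may be only part of what the source reports. "The series", "measured", "known", "first", "only" and "open" are said of these compounds alone.

Measured compounds:
compound 1, `CC(C)CCn1c(OC2CCN(C(=O)c3ccco3)CC2)nc2ccccc21`, 30.8% in an assay on isolated protein for inhibition of aldehyde dehydrogenase 1A1 (Homo sapiens), read by spectrophotometry, tested at 10 uM; a lower number here means less inhibition, a higher number more inhibition at the concentration tested (going by the name of the read-out)
compound 2, `Cc1cccc(Cn2c(OC3CCN(C(=O)C4CC4)CC3)nc3ccccc32)c1`, 80.6% in this assay

Of the two numbers, compound 2 stands highest in this assay; the nearest is compound 1, which lies well beyond the scatter below it. Going by the values given here, no step between two measured compounds that differ in one place is available, and compound 1 and compound 2 differ from each other in two places, so the two values show only that much and cannot be split between the two changes.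

Compound 3, `CC(C)CCn1c(OC2CCN(C(=O)C3CC3)CC2)nc2ccccc21`, has not yet been measured. It shares the amide side with compound 2 and differs from it in one place: isobutyl in place of 3-methylphenyl on a saturated chain carbon bound to an aromatic nitrogen. The six-membered aromatic ring of carbon goes and a chain of four carbons takes its place.

Among the compounds with values here, with no measured step of this kind to lean on, the expectation rests on the spread between compound 1 and compound 2. A step downward in this assay is expected, beyond the scatter, of about a number 30.6 percentage points lower from compound 2 to compound 3 (beyond the scatter). Compound 3 is therefore estimated at 50%, within a range from 25% to 75%.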

Compound 3, a percentage reported as inhibition, at one concentration (the size of the read-out at that concentration, not a potency): 56.4%
The estimate for compound 3 lay 6.4 percentage points below the measured number; measured number inside the range.
By their numbers in this assay, from the lowest: compound 1; then compound 3; then compound 2.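

In this assay, the change at the saturated chain carbon bound to an aromatic nitrogen can now be read on its own: isobutyl in place of 3-methylphenyl gives a number 24.2 percentage points lower from compound 2 to compound 3 (beyond the scatter) and so keeps a clear part of the inhibition even with no ring in the group at this place. The amide side also matters independently, since cyclopropyl in place of furan-2-yl on a carbonyl carbon gives a number 25.6 percentage points higher from compound 1 to compound 3 (beyond the scatter) with the isobutyl group held constant, and the wide gap first seen across two changes is therefore shared between both places. Nothing available bears on why either change moves the number.

Going by these compounds, it remains open whether the methyl group on the ring contributes to the higher number, which an unsubstituted phenyl in its place would test, and whether a longer chain or an amine at the end of the chain would keep the inhibition. Also open, on these data alone, is whether the two changes add up, which would need the 3-methylphenyl group tested together with the furan-2-yl amide in further close analogues.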